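The source may report more compounds than this note shows. Statements on the series, on what has been measured and on what is new or still open speak of the compounds shown alone.

In an ADME assay on HEK-293T cells (Homo sapiens) for cytotoxicity, read by CCK-8 assay, with a stated time of 48 h (a lower number here means a stronger inhibitor, a higher number a weaker inhibitor), compound 1 `O=S(=O)(NCCNC(=S)Nc1cc(C(F)(F)F)cc(C(F)(F)F)c1)c1ccc(-c2ccccc2O[C@H]2CC[C@@H](O)CC2)s1` reports only a limit, > 20000 nM. Among the measured compounds shown here, compound 2 `O=S(=O)(NCCNC(=S)Nc1cc(C(F)(F)F)cc(C(F)(F)F)c1)c1ccc(-c2ccccc2OCc2ccccc2)s1` gives 8500 nM, the only exact number so far. Compound 3 `O=S(=O)(NCCNC(=S)Nc1cc(C(F)(F)F)cc(C(F)(F)F)c1)c1ccc(-c2ccccc2Oc2ccc(O)c(O)c2)s1` carries 3,4-dihydroxyphenyl in place of the benzyl on the oxygen: 3,4-dihydroxyphenyl in place of benzyl on an oxygen on an aromatic ring. A single measured step changes the group at that place, an at least 2.3-fold lower number from compound 1 to compound 2 (0.37 log units; beyond the scatter), and there benzyl entered in place of 4-hydroxycyclohexyl and the number fell. Here benzyl leaves instead, so a modest move to a higher number is expected, on thin evidence, an estimated 1.4-fold higher number from compound 2 to compound 3 (0.15 log units; within the scatter). Compound 3 is estimated at 12000 nM, with an expected range of 4000 nM to 30000 nM.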

Compound 3, half-maximal inhibitory concentration: 12300 nM
For compound 3 the middle estimate is 1.0-fold (0.01 log units) below the measured one, and the stated range covers the measured number.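

In this assay, placing 3,4-dihydroxyphenyl on this oxygen instead of benzyl gives a 1.4-fold higher number from compound 2 to compound 3 (0.16 log units; within the scatter), so compound 2 and compound 3 cannot be told apart, and this position tolerates an aromatic ring bearing two hydroxyl groups. Against 4-hydroxycyclohexyl the step reads an at least 1.6-fold lower number from compound 1 to compound 3 (0.21 log units; that floor lies within the scatter), which establishes no real separation. The value for compound 1 is a limit, not a number: the limit of > 20000 nM in this assay, at which 1 of the 3 values shown sits.

As far as these compounds go, whether an aromatic ring with a single hydroxyl group would read the same remains open. So does the effect of an amine or a carboxylic acid on that ring.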